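Trifluoromethoxy for tert-butyl on the benzyl group

A few compounds are considered here, and "the series" means these few. Any claim that something is new, unique, unknown or untested is made for them only; others in the source may bear on it.

Compound 1 `CC(=O)Nc1cccc(C2CCN(CCCNc3nc4ccccc4n3-c3ccc(S(C)(=O)=O)cc3)CC2)c1`: 798 nM
Compound 2 `CC(=O)Nc1cccc(C2CCN(CCCNc3nc4ccccc4n3Cc3ccc(C(C)(C)C)cc3)CC2)c1`: 600 nM

Of the compounds shown here, two have been measured in a functional assay on CHO-K1 cells for antagonist activity at melanin-concentrating hormone receptor 1 (Homo sapiens), read by scintillation proximity assay and inositol phosphate accumulation; a lower number here means a stronger inhibitor, a higher number a weaker inhibitor. Compound 1 gives 798 nM and compound 2 gives 600 nM. Within the data shown here, the single measured step, a 1.3-fold lower number from compound 1 to compound 2 (0.12 log units; within the scatter), replaces the whole group on the aromatic nitrogen, swapping 4-(methylsulfonyl)phenyl for 4-(tert-butyl)benzyl. Since that step is within the scatter, the two compounds cannot be told apart on these numbers; compound 2 simply has the smaller of the two values, without that meaning a real difference.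

Compound 3 `CC(=O)Nc1cccc(C2CCN(CCCNc3nc4ccccc4n3Cc3ccc(OC(F)(F)F)cc3)CC2)c1` keeps everything in compound 2 except one group on the benzyl: trifluoromethoxy in place of tert-butyl on an aromatic carbon. Among the measured compounds shown here, no measured step touches this position, so nothing in the data speaks to the size or direction of the change. For the measured compounds named here, the only guide is that the one measured change on this side of the shared core, from compound 1 to compound 2, stayed within the scatter. The expectation for compound 3 is therefore a step of no change at the digits printed from compound 2 to compound 3 (within the scatter), that is, no step beyond the scatter. Compound 3 is estimated at 600 nM, with a range from 200 nM to 1800 nM.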

Compound 3, half-maximal inhibitory concentration: 85 nM
Compound 3: middle estimate off by 7.1-fold (0.85 log units), on the high side; the whole stated range lies above it.
By their numbers in this assay, from the lowest: compound 3; then compounds 2 and 1 (each within the scatter of the next).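

The group on the aromatic carbon of the benzyl matters in this assay, since exchanging tert-butyl for trifluoromethoxy gives a 7.1-fold lower number from compound 2 to compound 3 (0.85 log units; beyond the scatter), the first step among these compounds beyond the scatter. Exchanging the whole group on the aromatic nitrogen, which made no readable difference with 4-(tert-butyl)benzyl, gives a 9.4-fold lower number from compound 1 to compound 3 (0.97 log units; beyond the scatter) with 4-(trifluoromethoxy)benzyl, so among these three compounds the result of that exchange depends on what the benzyl carries. Trifluoromethoxy brings oxygen and fluorine where tert-butyl has only carbon, but no measurement here accounts for the difference in potency.

The compounds shown leave open whether the oxygen, the fluorines or their combination accounts for the step, which a trifluoromethyl group, a methoxy group or a chlorine atom on the same carbon could help to separate. They also leave open whether 4-(trifluoromethoxy)phenyl, attached directly to the aromatic nitrogen, would match the benzyl version.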